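One methoxy fewer on compound 1

A few compounds are considered here, and "the series" means these few. Any claim that something is new, unique, unknown or untested is made for them only; others in the source may bear on it.

Compound 1 `COc1cc(-c2cc(/C=C/C(=O)c3ccc(N)cc3)[nH]n2)cc(OC)c1OC` gives 110% in a functional assay on NCI/ADR-RES cells (Homo sapiens) for cytotoxicity, read by sulforhodamine B assay, with a stated time of 48 h, tested at 0.1 uM; a lower number here means a stronger effect, a higher number a weaker effect of the compound at the concentration tested. Compound 2 `COc1ccc(C(=O)/C=C/c2cc(-c3cc(OC)c(OC)c(OC)c3)n[nH]2)cc1OC` gives 95% in this assay, and compound 3 `COc1ccc(C(=O)/C=C/c2cc(-c3cc(OC)c(OC)c(OC)c3)n[nH]2)cc1` gives 97%. The step of a number 2 percentage points higher from compound 2 to compound 3 (within the scatter) arises from the change (hydrogen in place of methoxy on an aromatic carbon). Compound 4 `COc1ccc(-c2cc(/C=C/C(=O)c3ccc(N)cc3)[nH]n2)cc1OC` has not yet been measured in this assay; it differs from compound 1 by hydrogen in place of methoxy on an aromatic carbon, which is the same kind of change, though here the place is also meta to a methoxy group. The cores of compound 2 and compound 1 differ by 4-aminophenyl in place of 3,4-dimethoxyphenyl on a carbonyl carbon. Because the earlier step of a number 2 percentage points higher from compound 2 to compound 3 (within the scatter) stayed within the scatter, the step of no change at the digits printed from compound 1 to compound 4 (within the scatter) is expected to be of a similar size. Compound 4 is therefore estimated at 110%, most likely lying between 96% and 124%.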

Compound 4, a percentage reported as activity, at one concentration (the size of the read-out at that concentration, not a potency): 104%
Beside the measured number, compound 4's estimate is 6 percentage points above it; measured number inside the range.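

In this assay, hydrogen in place of methoxy on an aromatic carbon gives a number 6 percentage points lower from compound 1 to compound 4 (within the scatter). Set beside the earlier case, the change reads the same on both cores: the same change on two cores in this assay, a number 2 percentage points higher (within the scatter) from compound 2 to compound 3 and a number 6 percentage points lower (within the scatter) from compound 1 to compound 4, 8 percentage points apart, within the scatter of two such steps. Among the compounds shown here, this shows only that removing this methoxy group leaves the read-out within the scatter in these two pairs, at one concentration; it does not show that the same would hold on other cores or at other concentrations, and the methoxy group leaves a different aromatic ring in each pair.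

The compounds shown leave open what a hydroxy group, a chlorine atom or an ethoxy group would do on that aromatic carbon in this assay.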